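Expecting a Small Step for Compound 3

The source may hold more compounds than are shown below. What is called first, only, known or untested is meant among the compounds shown, and "the series" means these compounds.

In a functional assay on NCI-H460 cells (Homo sapiens) for inhibition, read by MTT assay, with a stated time of 24 h, tested at 100 ug/mL (a lower number here means less inhibition of growth, a higher number more inhibition of growth at the concentration tested), compound 1 (`O=C(CCCCC(S)CCS)Nc1ccccc1`) gives 25.4% and its chloro analogue, compound 2 (`O=C(CCCCC(S)CCS)Nc1cccc(Cl)c1`), gives 24.8% as its reading. These two values lie within the scatter of each other, the spread seen when the same measurement is repeated, so neither can be ranked above the other. Compound 3 (`O=C(CCCCC(S)CCS)Nc1ccc(Cl)cc1`) has not yet been measured. chloro in place of hydrogen on an aromatic carbon is the whole structural difference between compound 1 and compound 3, with chloro in place of hydrogen on an aromatic carbon, para to a large group. The same swap, at another place on the ring, has been measured once, with a number 0.6 percentage points lower from compound 1 to compound 2 (within the scatter) as the result, and on this single step no change beyond the scatter is expected in this assay in either direction. One step is thin evidence, and nothing measured yet shows how much the place of the chloro matters. The estimated step is a number 0.4 percentage points lower from compound 1 to compound 3 (within the scatter) as a working figure. For compound 3 the estimate is 25% with an expected range from 15% to 35% for a single measurement.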

Compound 3, percent growth inhibition at one concentration: 40.9%
For compound 3 the middle estimate is 15.9 percentage points below the measured one, outside the stated range (above it).
By their numbers in this assay, from the lowest: compounds 2 and 1 (each within the scatter of the next); then compound 3.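

Going by these compounds alone, the place of the chloro on the ring matters in this assay: with chloro in place of hydrogen para to a large group, the result is a number 15.5 percentage points higher from compound 1 to compound 3 (beyond the scatter) and this modest step is the first change beyond the scatter. With the same chloro at another place on the ring, compound 2 gives 24.8% and compound 3 gives 40.9%, so adding a chloro does not by itself raise the reading among these compounds; what differs is where it sits on the ring. The data show that this position responds to the swap, but nothing available explains the step.

On these data alone, whether this position favours chloro alone or would respond in the same way to another group stays open, and a fluoro, a bromo, a methoxy or an amine at the same place would help to settle that. It also remains unknown whether the step would hold with a shorter chain in the shared core, and the readings at one concentration give no dose-response curve for any of these compounds.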